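This account rests on a few compounds, and the source may have more. Where it says the series, first, only, none or still open, it means among the compounds named here.

Of the compounds shown here, three have been measured in a functional assay on SK-HEP1 cells (Homo sapiens) for antiproliferative activity; a higher number here means a weaker inhibitor of growth, a lower number a stronger inhibitor of growth. Compound 2 `CO/N=C(\C)COc1ccc2c(=O)cc(-c3ccccc3)oc2c1` gives 2000000 nM in this assay, the lowest of the three numbers. Compound 1 `C/C(COc1ccc2c(=O)cc(-c3ccccc3)oc2c1)=N\O` gives 2800000 nM in this assay, and the step of a 1.4-fold lower number from compound 1 to compound 2 (0.15 log units; within the scatter) lies within the scatter, so these two cannot be ranked. Among the compounds with values here, compound 3 `CO/N=C(/COc1c(-c2ccccc2)oc2ccccc2c1=O)c1ccccc1`, built on a differently arranged core, gives 7110000 nM in this assay; it is separated from compound 2 by a gap beyond the scatter, but no single-change step links the two, so only the values themselves can be set side by side. Compound 4 `CO/N=C(/COc1ccc2c(=O)cc(-c3ccccc3)oc2c1)c1ccccc1` is not yet measured. It differs from compound 2 by phenyl in place of methyl on a carbon with a double bond to nitrogen. Within the data shown here, the one measured step concerns a methyl on an oxygen rather than on this carbon and stayed within the scatter, so it does not speak directly to the change. Compound 3, which carries a phenyl on a carbon with a double bond to nitrogen, shows a higher number than compound 2, a hint rather than a measured step. Compound 4 is therefore expected to show a modestly higher number, a 2.0-fold higher number from compound 2 to compound 4 (0.30 log units; within the scatter). The estimate for compound 4 in this assay is 4000000 nM, with a likely range from 1500000 nM to 10000000 nM.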

Compound 4, concentration for 50% growth inhibition: 2000000 nM
Estimate against measurement, compound 4: 2.0-fold (0.30 log units) above; low and high end bracket the measured number.
By their numbers in this assay, from the lowest: compounds 2, 4 and 1 (each within the scatter of the next); then compound 3.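

Phenyl in place of methyl on a carbon with a double bond to nitrogen gives no change at the digits printed from compound 2 to compound 4 (within the scatter) in this assay. Within the data shown here, this is the first measured step at this carbon: the earlier step concerned a methyl on an oxygen, whereas here one six-membered aromatic ring replaces a single carbon and compound 2 and compound 4 still cannot be told apart. No measurement available here accounts for this result.

From the compounds shown here alone, it remains open whether other groups on this carbon, such as an amine, a carboxylic acid or a longer chain, would also stay within the scatter of compound 2. Also open, going by these compounds, is whether any group at this place could give a number clearly lower than those of compound 2 and compound 4.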